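A Pyridyl Amide Replaces a Dimethylphenyl Amide

This account rests on a few compounds, and the source may have more. Where it says the series, first, only, none or still open, it means among the compounds named here.

Compound 1 `Cc1cc(C)cc(NC(=O)COc2cc(C)nc3ccc(F)cc23)c1`: 5.79
Compound 2 `CCC(Oc1cc(C)nc2ccc(OC)cc12)C(=O)Nc1cc(C)cc(C)c1`: 6.28
Compound 3 `COc1ccc2nc(C)cc(OCC(=O)Nc3cc(C)ccc3C)c2c1`: 5.05

Of the compounds shown here, three have been measured in a physicochemical assay for lipophilicity, read by HPLC, in phosphate buffer, measured as chromatographic lipophilicity, at pH 7.4; a lower number here means a more polar compound, a higher number a more lipophilic compound. Compound 1 gives 5.79, compound 2 gives 6.28, and compound 3 gives 5.05. Compound 3 therefore stands at the lowest of the three numbers; the value of compound 1 lies closer to it, that of compound 2 further away, and both gaps exceed the usual scatter.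

Compound 4 `COc1ccc2nc(C)cc(OCC(=O)Nc3cccnc3)c2c1` has not yet been measured. It differs from compound 3 in one place: pyridin-3-yl in place of 2,5-dimethylphenyl on an amide-type nitrogen. The group that leaves carries no hydrogen-bond acceptor, the group that enters carries one, and the entering group has fewer heavy atoms.

Within the data shown here, no measured pair in this set shows a step of this kind, so the expectation rests on the structural change alone. Compound 4 is expected to give a clearly lower number than compound 3, a step from a number 2.05 log units lower from compound 3 to compound 4 (beyond the scatter) well beyond the scatter. The estimate for compound 4 is 3, with a range from 2.3 to 3.7.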

Compound 4, distribution coefficient: 2.46
Estimate against measurement, compound 4: 0.54 log units above; low and high end bracket the measured number.
By their numbers in this assay, from the lowest: compound 4; then compound 3; then compound 1; then compound 2.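

In this assay, among these compounds, replacing 2,5-dimethylphenyl with pyridin-3-yl on the amide-type nitrogen gives a number 2.59 log units lower from compound 3 to compound 4 (beyond the scatter), the first step in this set that can be read at a single place. It shows that the group on this nitrogen can by itself move the number by a large amount while the rest of compound 3 stays unchanged. No measurement at hand explains the size of this step.

Going by these compounds, whether a plain phenyl on this nitrogen would stand nearer to compound 3 or to compound 4 remains open, so the share of the two methyl groups and that of the ring nitrogen cannot be separated. Also open, on these data alone, is whether the same exchange would produce a step of similar size in compound 1 or compound 2.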